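Methoxy to bromo on the benzoate ester series

The compounds below may be only part of what the source reports. "The series", "measured", "known", "first", "only" and "open" are said of these compounds alone.

Values in a physicochemical assay for lipophilicity, measured as octanol-water partition (on this read-out higher numbers stand for higher lipophilicity and lower numbers for lower lipophilicity), so far:
Compound 1 `COc1ccccc1C(=O)O[C@@H]1C[C@H](C)CC[C@H]1C(C)C` gives 4.57
Compound 2 `Cc1ccc(C(=O)O[C@@H]2C[C@H](C)CC[C@H]2C(C)C)cc1` gives 5.29
Compound 3 `CC(C)[C@@H]1CC[C@@H](C)C[C@H]1OC(=O)c1ccc(Br)cc1` gives 5.61

Of these three, compound 1 has the lowest number in this assay, and its gaps to compound 2 and compound 3 both lie beyond the scatter. The next compound is compound 4 `CC(C)[C@@H]1CC[C@@H](C)C[C@H]1OC(=O)c1ccccc1Br`, still unmeasured. The change is bromo in place of methoxy on an aromatic carbon, ortho to a large group.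

Among the compounds with values here, one measured step bears on this: a number 0.32 log units higher from compound 2 to compound 3 (beyond the scatter), a modest rise for bromo in place of methyl on an aromatic carbon. Within the data shown here, it has a different leaving group, and no measured pair isolates methoxy against bromo, so it offers only loose guidance. A rise larger than that step is expected, as compound 1 at 4.57 sits well under compound 3 at 5.61, which also carries bromo. The estimated change is a number 0.73 log units higher from compound 1 to compound 4 (beyond the scatter). For compound 4 the expected value is 5.3, with an estimated range of 4.95 to 5.65.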

Compound 4, partition coefficient: 5.61
The estimate for compound 4 lay 0.31 log units below the measured number; the range from low to high includes it.
By their numbers in this assay, from the lowest: compound 1; then compound 2; then compounds 3 and 4 (each within the scatter of the next).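

In this assay, within the data shown here, the exchange of bromo in place of methoxy on an aromatic carbon, ortho to a large group, can now be read directly as a number 1.04 log units higher from compound 1 to compound 4 (beyond the scatter) and counts as large, whereas the only earlier step, bromo in place of methyl, was the modest a number 0.32 log units higher from compound 2 to compound 3 (beyond the scatter) on a different substituent. The two bromo compounds now stand level, with compound 3 at 5.61 and compound 4 at 5.61 within the scatter of each other, so their numbers show no readable difference. No measurement shown here accounts for the size of the methoxy to bromo step.

From the compounds shown here alone, whether an amine, a carboxylic acid or a longer alkoxy chain at this position would read nearer compound 1 or compound 4 stays open. Also open, going by these compounds, is whether the same exchange gives a step of this size on another aromatic carbon.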